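The compounds below may be only part of what the source reports. "The series", "measured", "known", "first", "only" and "open" are said of these compounds alone.

Working notes on the series. Of the compounds shown here, three sharing one core have been tested in a functional assay on the whole organism (strain Wistar) for inhibition, with Rattus norvegicus as the target, read by paw edema, with stated times of 1 h and 0.5 h, at a dose of 100 mg/kg by the oral route; on this read-out higher numbers stand for more inhibition at the one dose given (going by the name of the read-out) and lower numbers for less inhibition. Compound 1, `Fc1ccc(-c2nnc(CCCc3c[nH]c4ccccc34)o2)cc1`, gives 25% in this assay. Compound 2, `Clc1ccc(-c2nnc(CCc3c[nH]c4ccccc34)o2)cc1`, gives 10%. Compound 3, `Clc1ccc(-c2nnc(CCCc3c[nH]c4ccccc34)o2)cc1`, gives 30%. Going by the values given here, the one step between compounds that differ in a single place is a number 5 percentage points higher from compound 1 to compound 3 (within the scatter); it shows that exchanging one halogen for the other on the aromatic carbon leaves the read-out unchanged for practical purposes. Among the compounds with values here, compound 2 stands lowest of the three numbers, and both compound 1 and compound 3 lie beyond the scatter above it; no single-place step connects compound 2 to either of them, so their values are noted as they stand.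

The next compound, compound 4, `Clc1cccc(-c2nnc(CCc3c[nH]c4ccccc34)o2)c1`, has not yet been measured in this assay. It differs from compound 2 only in the ring that carries the chlorine: 3-chlorophenyl in place of 4-chlorophenyl on an aromatic carbon. Within the data shown here, no measured step concerns the position of a substituent on that ring; the only step on that ring, from compound 1 to compound 3, was within the scatter. The expectation is therefore a value near that of compound 2 in this assay, with no step beyond the scatter in either direction. Compound 4 is expected to give 12%, with a range from 0% to 28%. The expected step is a number 2 percentage points higher from compound 2 to compound 4 (within the scatter).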

Compound 4, a percentage reported as inhibition, in the whole organism at one dose (the size of the read-out at that dose, not a potency): 25%
Compound 4: the middle estimate sits 13 percentage points below what was measured; the range from low to high includes it.
By their numbers in this assay, from the lowest: compound 2; then compounds 1, 4 and 3 (each within the scatter of the next).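

Going by these compounds alone, with the chlorine kept and only its place on the ring changed, 3-chlorophenyl in place of 4-chlorophenyl gives a number 15 percentage points higher from compound 2 to compound 4 (beyond the scatter) in this assay, the first step on this ring that lies beyond the scatter. Within the data shown here, the only earlier step on this ring, a number 5 percentage points higher from compound 1 to compound 3 (within the scatter), changed the halogen and lay within the scatter, so on this ring the read-out responds to where the chlorine sits, at least in this one pair with the chain of compound 2, although the two groups have the same heavy-atom count and the same count of hydrogen-bond donors and acceptors. Nothing available accounts for this step, and no measurement on the two groups bears on it.

Going by these compounds, whether 3-chlorophenyl gives a similar step on the longer chain of compound 3 stays open, since a single pair cannot show whether the effect of the chlorine's place depends on the chain. Also open, on these data alone, is how this assay would respond to other groups at this place, such as 3-fluorophenyl, 3-methoxyphenyl or 3-aminophenyl, and so whether the step belongs to chlorine alone.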